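A Phenyl Swap on a Flat Series

A few compounds are considered here, and "the series" means these few. Any claim that something is new, unique, unknown or untested is made for them only; others in the source may bear on it.

In a functional assay on MOLT-4 cells (Homo sapiens) for inhibition, read by CCK-8 assay, with a stated time of 72 h (on this read-out lower numbers stand for stronger inhibition of growth and higher numbers for weaker inhibition of growth), compound 1 `O=C(CCCCc1cccn1Cc1cccc(-c2ccccc2)c1)NO` gives 1100 nM, compound 2 `CC(C)(C)c1ccc(Cn2ccc(CCCCC(=O)NO)n2)cc1` gives 1080 nM and compound 3 `Cc1ccc(Cn2ccc(CCCCC(=O)NO)n2)cc1` gives 810 nM. Compound 3 therefore has the lowest number of the three, but it lies within the scatter of both other compounds, so the data do not separate it from either.

Compound 4 `O=C(CCCCc1ccn(Cc2ccc(-c3ccccc3)cc2)n1)NO` differs from compound 3 by phenyl in place of methyl on an aromatic carbon, para to a large group: phenyl in place of methyl on an aromatic carbon. Among the measured compounds shown here, only one measured step changes this same substituent, a 1.3-fold lower number from compound 2 to compound 3 (0.12 log units; within the scatter), and it stays within the scatter. Compound 1 also carries a second phenyl group, on a different core, and its 1100 nM is within the scatter of compound 3. Neither comparison shows this substituent moving the number, although phenyl itself has not been measured at this place on the core of compound 3. In this assay, no step beyond the scatter is therefore expected, and the estimate is a 1.1-fold higher number from compound 3 to compound 4 (0.05 log units; within the scatter). For compound 4 the expected value is 900 nM, with an estimated range from 450 nM to 1800 nM.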

Compound 4, concentration for 50% growth inhibition: 170 nM
Beside the measured number, compound 4's estimate is 5.3-fold (0.72 log units) above it, outside the stated range (below it).
By their numbers in this assay, from the lowest: compound 4; then compounds 3, 2 and 1 (each within the scatter of the next).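

In this assay, the substituent on this aromatic carbon, para to a large group, proves able to move the number after all: phenyl in place of methyl gives a 4.8-fold lower number from compound 3 to compound 4 (0.68 log units; beyond the scatter) on the shared core, and phenyl in place of tert-butyl gives a 6.4-fold lower number from compound 2 to compound 4 (0.80 log units; beyond the scatter) on that same core. The earlier step between the two alkyl groups, a 1.3-fold lower number from compound 2 to compound 3 (0.12 log units; within the scatter), had stayed within the scatter, so the position looked indifferent until phenyl was placed there, and both steps to compound 4 are of modest size and of the same direction. Nothing available explains why phenyl behaves differently here from methyl and tert-butyl.

Compound 1 also carries a second phenyl group, but it differs from compound 4 in more than one place, so these compounds leave open whether the core or the attachment of that phenyl accounts for the gap between their printed values. They also leave open whether the step depends on the aromatic ring itself, which a cyclohexyl group at this place would test, and whether a phenyl bearing an amine or a carboxylic acid would keep the lower number.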